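Lengthening the alkenyl chain one step further

The compounds below may be only part of what the source reports. "The series", "measured", "known", "first", "only" and "open" are said of these compounds alone.

Among the compounds with values here, in a functional assay on LoVo cells (Homo sapiens) for inhibition, read by colorimetric assay and MTT assay, with a stated time of 72 h (on this read-out lower numbers stand for stronger inhibition and higher numbers for weaker inhibition), compound 1 (`C=CCCCCOc1ccccc1-c1cnc(OCCC=C)n1C`) gives 12000 nM and compound 2 (`C=CCCCCOc1ccccc1-c1cnc(OCCCC=C)n1C`) gives 4000 nM as the lower of only two numbers so far. Within the data shown here, one measured step bears on what comes next: a 3.0-fold lower number from compound 1 to compound 2 (0.48 log units; beyond the scatter) is a modest change beyond the scatter, with allyl in place of vinyl on a saturated chain carbon, two bonds along the chain from an oxygen on an aromatic ring. Compound 3 (`C=CCCCCOc1ccccc1-c1cnc(OCCCCC=C)n1C`) carries the same kind of change one place further out (allyl in place of vinyl on a saturated chain carbon, three bonds along the chain from an oxygen on an aromatic ring) on the same chain. A single step sets no trend, so only a somewhat smaller move in the same direction is expected. The expected change is a 2.2-fold lower number from compound 2 to compound 3 (0.35 log units; beyond the scatter) in this assay as a lower number. Compound 3 is estimated at 1800 nM with an expected range from 700 nM to 5000 nM in this read-out.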

Compound 3, half-maximal inhibitory concentration: 5000 nM
Compound 3: middle estimate off by 2.8-fold (0.44 log units), on the low side; measured number inside the range.
By their numbers in this assay, from the lowest: compounds 2 and 3 (each within the scatter of the next); then compound 1.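

In this assay, the further extension on this chain does not carry on the earlier drop: the result is a 1.3-fold higher number from compound 2 to compound 3 (0.10 log units; within the scatter), so compound 2 and compound 3 cannot be told apart at this position. Measured across both extensions, the change remains a 2.4-fold lower number from compound 1 to compound 3 (0.38 log units; beyond the scatter), which means that the difference from compound 1 survives even though the last added carbon brings nothing that can be resolved. No experimental evidence accounts for the contrast between the first extension and the second.

Three chain lengths cannot show whether the values stay level or shift with a longer chain. From the compounds shown here alone, it also remains open whether a saturated hexyl chain or a terminal amine at this end of the chain would give a number like that of compound 3.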